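From Acetyl to Propanoyl in a Cytotoxicity Series

The source may hold more compounds than are shown below. What is called first, only, known or untested is meant among the compounds shown, and "the series" means these compounds.

Three compounds have been measured in a functional assay on ACHN cells (Homo sapiens) for cytotoxicity, read by sulforhodamine B assay, with a stated time of 72 h; on this read-out higher numbers stand for weaker inhibition of growth and lower numbers for stronger inhibition of growth:
Compound 1, `O=C(Nc1ccccc1C(F)(F)F)C1CCc2ccccc2N1C(=O)c1cccc(Cl)c1`, gives 526 nM.
Compound 2, `O=C(Nc1ccccc1C(F)(F)F)C1CCc2ccccc2N1`, gives 57600 nM.
Compound 3, `CC(=O)N1c2ccccc2CCC1C(=O)Nc1ccccc1C(F)(F)F`, gives only the limit > 80000 nM.

Compound 3 thus stands at the boundary of this assay, not at a number; it is one of the values at the limit of > 80000 nM in this assay, at which 1 of the 3 values shown sits. Compound 4, `CCC(=O)N1c2ccccc2CCC1C(=O)Nc1ccccc1C(F)(F)F`, is not yet measured and differs from compound 3 by methyl in place of hydrogen on a saturated chain carbon bound to a carbonyl carbon. Going by the values given here, two measured steps bear on it: an at least 150-fold higher number from compound 1 to compound 3 (2.18 log units; beyond the scatter) shows how much was lost when methyl replaced 3-chlorophenyl, while an at least 1.3-fold higher number from compound 2 to compound 3 (0.14 log units; that floor lies within the scatter) shows a floor within the scatter. Adding one carbon to a compound already at the limit is expected to give no step beyond the scatter, a number no higher from compound 3 to compound 4 (the limit leaves the size open). Compound 4 is therefore estimated at 80000 nM, between 35000 nM and 200000 nM, most likely again reported only as a limit.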

Compound 4, concentration for 50% growth inhibition: > 80000 nM
Compound 4 was reported as a limit (the forecaster's own chance of this, stated with the estimate: 70%); the middle value lies on the limit itself.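

In this assay, compound 4 sits at a limit of the assay, the same limit as compound 3: the limit of > 80000 nM in this assay, at which 2 of the 4 values shown sit. The step between these two cannot be read, so the effect of the added carbon stays hidden. Ethyl on the carbonyl carbon does not recover the growth inhibition seen with 3-chlorophenyl, with an at least 150-fold higher number from compound 1 to compound 4 (2.18 log units; beyond the scatter), while propanoyl in place of hydrogen gives only an at least 1.3-fold higher number from compound 2 to compound 4 (0.14 log units; that floor lies within the scatter).

As far as these compounds go, whether a longer chain such as butanoyl, or an unsubstituted phenyl, on the carbonyl carbon would bring measurable growth inhibition back remains open.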